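Side-chain group exchange from compound 2 to compound 3

A few compounds are considered here, and "the series" means these few. Any claim that something is new, unique, unknown or untested is made for them only; others in the source may bear on it.

Going by the values given here, in a functional assay on HeLa cells (Homo sapiens) for antiproliferative activity, read by MTT assay, with a stated time of 72 h (on this read-out lower numbers stand for stronger inhibition and higher numbers for weaker inhibition), only two compounds have numbers so far. Compound 1 (`O=C1NC(O)(CCn2cnc3cc[nH]c3c2=O)C(OCc2ccccc2)=C1OCc1ccccc1`) gives 92000 nM, and compound 2 (`O=C1NC(O)(CCn2cnc3cncc(Br)c32)C(OCc2ccccc2)=C1OCc1ccccc1`) gives 77000 nM. The two lie within the scatter of each other, so compound 2 cannot be ranked against compound 1, and both numbers stand for weak inhibition.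

Compound 3 (`O=C1NC(O)(CCn2cnc3ccnc(Cl)c32)C(OCc2ccccc2)=C1OCc1ccccc1`) is not yet measured. Its change from compound 2 is a group of 10 heavy atoms (6 carbon, 3 nitrogen, 1 chlorine; one five-membered aromatic ring with 2 hetero atoms, one six-membered aromatic ring with 1 hetero atom) in place of a group of 10 heavy atoms (6 carbon, 3 nitrogen, 1 bromine; one five-membered aromatic ring with 2 hetero atoms, one six-membered aromatic ring with 1 hetero atom), on a saturated chain carbon, two bonds along the chain from a saturated ring carbon. The ring counts and the counted donors and acceptors of the group stay the same, and the halogen changes from bromine to chlorine.

Among the compounds with values here, the only measured step that bears on this is a 1.2-fold lower number from compound 1 to compound 2 (0.08 log units; within the scatter). That step exchanged one group of the same size for another, and this assay showed no shift beyond the scatter. Within the data shown here, no measured pair isolates bromine against chlorine, so this evidence is thin. No step beyond the scatter is expected in either direction, and the estimated step is a 1.0-fold higher number from compound 2 to compound 3 (0.02 log units; within the scatter). For compound 3 the expected value is 80000 nM, with an estimated range of 40000 nM to 160000 nM.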

Compound 3, half-maximal inhibitory concentration: 21000 nM
Estimate against measurement, compound 3: 3.8-fold (0.58 log units) above, and the stated range ends above it.
By their numbers in this assay, from the lowest: compound 3; then compounds 2 and 1 (each within the scatter of the next).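

In this assay, the side-chain position proved able to shift the number beyond the scatter: a 3.7-fold lower number from compound 2 to compound 3 (0.56 log units; beyond the scatter) and a 4.4-fold lower number from compound 1 to compound 3 (0.64 log units; beyond the scatter), whereas a 1.2-fold lower number from compound 1 to compound 2 (0.08 log units; within the scatter) showed no such separation. The groups in compound 2 and compound 3 match in heavy-atom count, ring counts, and counted donors and acceptors, so those counts do not separate them; the halogen changes from bromine to chlorine, and the structures also show the ring nitrogen placed differently, so the step cannot be assigned to the halogen alone. Nothing available explains the step.

Open, from the compounds shown here alone, is whether the halogen or the ring nitrogen placement carries the step, which would take a pair that differs in only one of them. Also open, going by these compounds, is how far the number can fall below that of compound 3, which gives 21000 nM, with an amine or a methoxy group in place of the chlorine, or with a longer chain carrying the group.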